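A few compounds are considered here, and "the series" means these few. Any claim that something is new, unique, unknown or untested is made for them only; others in the source may bear on it.

In a functional assay on HeLa cells (Homo sapiens) for cytotoxicity, read by MTT assay, with a stated time of 24 h (on this read-out lower numbers stand for stronger inhibition and higher numbers for weaker inhibition), compound 1 (`Nc1nc(OCc2cn(-c3n[nH]c4nc(C(F)(F)F)ccc34)nn2)cc(C(F)(F)F)n1`) gives > 100000 nM, which is a limit of the assay and not a number. Compound 2 (`Nc1nc(C(F)(F)F)cc(=O)n1Cc1cn(-c2nn(CCC(F)(F)C(F)(F)C(F)(F)C(F)(F)C(F)(F)C(F)(F)C(F)(F)C(F)(F)F)c3nc(C(F)(F)F)ccc23)nn1`) gives > 100000 nM, which is also a limit, so no number is available for it. Compound 3 (`Nc1nc(OCc2cn(-c3nn(CCC(F)(F)C(F)(F)C(F)(F)C(F)(F)C(F)(F)C(F)(F)C(F)(F)C(F)(F)F)c4nc(C(F)(F)F)ccc34)nn2)cc(C(F)(F)F)n1`) has the same atoms as compound 2, joined differently: a group of 12 heavy atoms (5 carbon, 3 nitrogen, 1 oxygen, 3 fluorine; one six-membered aromatic ring with 2 hetero atoms) in place of a group of 12 heavy atoms (5 carbon, 3 nitrogen, 1 oxygen, 3 fluorine; one six-membered aromatic ring with 2 hetero atoms), on a saturated chain carbon bound to an aromatic carbon. The (2-amino-6-(trifluoromethyl)pyrimidin-4-yl)oxy group enters on a saturated chain carbon bound to an aromatic carbon. In this assay, the expected change is none beyond the scatter, with an estimated a number no higher from compound 2 to compound 3 (the limit leaves the size open). Compound 3 is expected to give an estimated 100000 nM, within a range from 50000 nM to 200000 nM.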

Compound 3, half-maximal inhibitory concentration: > 100000 nM
Compound 3 gave a limit, no number (the forecaster's own chance of this, stated with the estimate: 85%); the middle value lies on the limit itself.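

No step can be read from compound 2 to compound 3, because both values are limits and not numbers: the limit of > 100000 nM in this assay, at which 3 of the 3 values shown sit. The compounds shown leave open whether either arrangement of the same atoms differs from the other in this assay.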